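The source may report more compounds than this note shows. Statements on the series, on what has been measured and on what is new or still open speak of the compounds shown alone.

Measured compounds, in an assay on isolated protein for activation of cGMP-dependent protein kinase 1 (Homo sapiens), read by ADP-Glo, with stated times of 120 min and 40 min; a lower number here means that less compound is needed, a higher number that more compound is needed for the effect:
compound 1 `O=C(O)c1ccc2c(CN3CCC[C@H](O[C@H](CO)c4cc(Cl)cc(Cl)c4)[C@@H]3c3ccccc3)c[nH]c2c1` gives 22000 nM;
compound 2 `OC[C@@H](O[C@H]1CCCN(Cc2cccc3nonc23)[C@H]1c1ccccc1)c1cc(Cl)cc(Cl)c1` gives 8000 nM;
compound 3 `Clc1cc(Cl)cc(CO[C@H]2CCCN(Cc3ncco3)[C@H]2c2ccccc2)c1` gives only a limit of the assay, > 200000 nM.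

Compound 3 thus stands at the limit (the limit of > 200000 nM in this assay, at which 1 of the 3 values shown sits), with no number of its own. Compound 4 `Clc1cc(Cl)cc(CO[C@H]2CCCN(Cc3ccccc3)[C@H]2c2ccccc2)c1` differs from it by one change: phenyl in place of 1,3-oxazol-2-yl on a saturated chain carbon bound to an amine nitrogen in a ring. For the measured compounds named here, the only measured step, a 2.8-fold lower number from compound 1 to compound 2 (0.44 log units; beyond the scatter), swaps a different pair of groups at the same place, so no measured step bears directly on this change. On that basis no size or direction beyond the scatter can be expected, and compound 4 is estimated to stay near the limit, at 150000 nM, within 30000 nM to 400000 nM, an expected step of an at least 1.3-fold lower number from compound 3 to compound 4 (0.12 log units; that floor lies within the scatter).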

Compound 4, half-maximal effective concentration: > 200000 nM
Compound 4: no number, only a limit; the forecaster's own chance of this, stated with the estimate: 55%; at least 1.3-fold (0.12 log units) between middle value and limit.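

Compound 3 and compound 4 both give only a limit, so the change from 1,3-oxazol-2-yl to phenyl cannot be read as a step: the limit of > 200000 nM in this assay, at which 2 of the 4 values shown sit.

Which of these two groups needs less compound for the effect, and by how much, stays open.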